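Swapping an aromatic amide substituent for a pentyl chain

The source may hold more compounds than are shown below. What is called first, only, known or untested is meant among the compounds shown, and "the series" means these compounds.

Compound 1 `COc1ccc2nc(C)cc(OCC(=O)Nc3ccc(OC)c(OC)c3)c2c1` in an ADME assay on HepG2 cells (Homo sapiens) for cytotoxicity, read by trypan blue exclusion, with a stated time of 48 h, in the presence of a further agent that is not named here (a higher number here means that more compound is tolerated, a lower number that less compound is tolerated), reaches only the limit > 131000 nM.
Compound 2 `COc1ccc2nc(C)cc(OCC(=O)Nc3cccc(Br)c3)c2c1` in this assay likewise reaches only the limit > 125000 nM.

Both readings are limits of the assay, not numbers. Compound 2 therefore stands at the limit of > 125000 nM in this assay, at which 1 of the 2 values shown sits. Compound 1 sits at the limit of > 131000 nM in this assay, at which 1 of the 2 values shown sits. Compound 3 `CCCCCNC(=O)COc1cc(C)nc2ccc(OC)cc12` differs from compound 2 by pentyl in place of 3-bromophenyl on an amide-type nitrogen: pentyl enters where 3-bromophenyl leaves, on an amide-type nitrogen. With both measured compounds at their limits, the expected step is a number no higher from compound 2 to compound 3 (the limit leaves the size open), nothing beyond the scatter. Compound 3 is estimated at 125000 nM, with a range from 60000 nM to 250000 nM.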

Compound 3, half-maximal cytotoxic concentration: > 158000 nM
Compound 3 ended at the assay's limit; the forecaster's own chance of this, stated with the estimate: 80%; at least 1.2-fold (0.10 log units) between middle value and limit.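

In this assay, going by these compounds alone, compound 2 and compound 3 both gave only limits, and no step between them can be read. The compounds shown leave open what concentration harms the cells, and whether pentyl and 3-bromophenyl differ at all.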